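The compounds below may be only part of what the source reports. "The series", "measured", "known", "first", "only" and "open" are said of these compounds alone.

In a functional assay on HepG2 cells (Homo sapiens) for antiproliferative activity, read by MTT assay, with a stated time of 72 h (a higher number here means a weaker inhibitor, a lower number a stronger inhibitor), compound 1 `NC1=NC2(CCOCC2)N(OCCCOc2ccccc2)C(N)=N1` is recorded as "not determined" (no result reported), and compound 3 `NC1=NC2(CCOCC2)N(OCCCOc2ccc(F)cc2)C(N)=N1` is recorded as "not determined" (no result reported), so compound 3 has no number from which to measure a step. Compound 2 `CC(C)(C)c1ccc(OCCCON2C(N)=NC(N)=NC23CCSCC3)cc1` alone has a number, 70 nM. Compound 4 `NC1=NC2(CCOCC2)N(OCCCOc2ccc(Cl)c(Cl)c2)C(N)=N1` follows from compound 3 with 3,4-dichlorophenyl in place of 4-fluorophenyl on an oxygen on a saturated carbon. For the measured compounds named here, no measured step shows what such a change does in this assay, so any expectation is loose: a modest step toward stronger inhibition is expected, its size unanchored. Going by the values given here, the only numerical reference is compound 2 at 70 nM. Compound 4 is expected at about 200 nM, with an estimated range of 40 nM to 1000 nM.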

Compound 4, half-maximal inhibitory concentration: 380 nM
Estimate against measurement, compound 4: 1.9-fold (0.28 log units) below; the range from low to high includes it.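

No step can be read between compound 3 and compound 4 in this assay, where compound 4 gives 380 nM. Nothing shown explains this value. From the compounds shown here alone, what swapping 4-fluorophenyl for 3,4-dichlorophenyl does to inhibition stays open.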